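A Methyl Added to the Thiazole of Compound 2

The compounds below may be only part of what the source reports. "The series", "measured", "known", "first", "only" and "open" are said of these compounds alone.

Of the compounds shown here, two have been measured in a functional assay on BMDM cells (Mus musculus, strain C57BL/6) for inhibition, with a stated time of 2 days; on this read-out higher numbers stand for weaker inhibition and lower numbers for stronger inhibition. Within the data shown here, compound 1 `Nc1cccc(-c2cn(CC(=O)Nc3nccs3)nn2)c1` gives 1270 nM, and compound 2 `O=C(Cn1cc(-c2ccccc2Cl)nn1)Nc1nccs1` gives 60 nM, the lowest of the two numbers so far; the only step seen is a 21-fold lower number from compound 1 to compound 2 (1.33 log units; beyond the scatter). Compound 3 `Cc1csc(NC(=O)Cn2cc(-c3ccccc3Cl)nn2)n1` differs from compound 2 in one place: methyl in place of hydrogen on an aromatic carbon, which turns the 1,3-thiazol-2-yl group into a 4-methyl-1,3-thiazol-2-yl group. Among the measured compounds shown here, no measured step touches that part of the shared core; the step from compound 1 to compound 2 concerns the other ring and says nothing about a methyl here. With nothing to point either way, the expectation for compound 3 in this assay is a step of a 1.2-fold higher number from compound 2 to compound 3 (0.07 log units; within the scatter), within the scatter. Compound 3 is therefore estimated at 70 nM, with a range from 25 nM to 200 nM.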

Compound 3, half-maximal inhibitory concentration: 1240 nM
The estimate for compound 3 lay 18-fold (1.25 log units) below the measured number, and the stated range ends below it.
By their numbers in this assay, from the lowest: compound 2; then compounds 3 and 1 (each within the scatter of the next).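

In this assay the 1,3-thiazol-2-yl group turns out not to be a silent part of the shared core: one added methyl, on an aromatic carbon next to the ring nitrogen, gives a 21-fold higher number from compound 2 to compound 3 (1.32 log units; beyond the scatter). Among these compounds, this is the first measured change at this position, and it shows that a single heavy atom here can move the number well beyond the scatter, towards weaker inhibition. No measurement shown gives a reason for this loss.

Still open, as far as these compounds go, is whether other groups at this carbon, such as an amine, a chlorine atom or a longer chain like ethyl, would bring a step of similar size. Also open, from the compounds shown here alone, is whether the same methyl would act alike with the 3-aminophenyl group of compound 1 on the other ring.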